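The compounds below may be only part of what the source reports. "The series", "measured", "known", "first", "only" and "open" are said of these compounds alone.

In a functional assay on MV4-11 cells (Homo sapiens) for inhibition, read by resazurin assay, with a stated time of 72 h (on this read-out higher numbers stand for weaker inhibition of growth and lower numbers for stronger inhibition of growth), compound 1 `COc1ccc(Nc2nccc(-c3sc(SC)nc3C)n2)c(OC)c1` gives 530 nM and compound 2 `COc1ccc(Nc2nccc(-c3sc(SC(C)C)nc3C)n2)c(OC)c1` gives 5670 nM, so compound 2 holds the higher of the two numbers and inhibits growth more weakly. These two compounds differ in one place, and putting isopropyl in place of methyl on a sulfur gives an 11-fold higher number from compound 1 to compound 2 (1.03 log units; beyond the scatter). The next structure, compound 3 `COCCSc1nc(C)c(-c2ccnc(Nc3ccc(OC)cc3OC)n2)s1`, keeps the shared core and changes that same group again, with 2-methoxyethyl in place of isopropyl on a sulfur. For the measured compounds named here, only the one measured step bears on this change. It shows that the group on this sulfur can shift the number strongly, but neither measured compound carries an oxygen in that group, so it is a rough guide. Compound 3 is expected to recover part of the ground lost in an 11-fold higher number from compound 1 to compound 2 (1.03 log units; beyond the scatter), though not all of it. The expected change is a 2.8-fold lower number from compound 2 to compound 3 (0.45 log units; beyond the scatter), a moderate move towards stronger inhibition that remains uncertain. For compound 3 the estimated value is 2000 nM, with a range from 700 nM to 6000 nM.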

Compound 3, concentration for 50% growth inhibition: 810 nM
The estimate for compound 3 lay 2.5-fold (0.39 log units) above the measured number, within the range that was stated.
By their numbers in this assay, from the lowest: compounds 1 and 3 (each within the scatter of the next); then compound 2.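

In this assay the change to 2-methoxyethyl gives a 7.0-fold lower number from compound 2 to compound 3 (0.85 log units; beyond the scatter), so the large rise seen with isopropyl does not apply to every group larger than methyl on this sulfur. Compared with the methyl group, the same chain gives a 1.5-fold higher number from compound 1 to compound 3 (0.18 log units; within the scatter), which leaves these two compounds level on this read-out. The number therefore does not simply climb with the heavy-atom count of the group: 2-methoxyethyl holds more heavy atoms than isopropyl, and compound 3 goes against any such trend. No accompanying measurement explains why these groups behave differently.

It remains open whether the oxygen or the unbranched shape of 2-methoxyethyl sets it apart from isopropyl, a question that a plain propyl chain, absent from the compounds shown, could help to separate. Also open, from the compounds shown here alone, is how a chain on this sulfur carrying an amine or a carboxylic acid would read, and whether a longer ether chain would stay level with the methyl group.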